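Extending a butylsulfanyl chain: expected cell tolerance

A few compounds are considered here, and "the series" means these few. Any claim that something is new, unique, unknown or untested is made for them only; others in the source may bear on it.

compound 1, `CCCCCCCCOc1nc(N)nc2c1ncn2/C=C1/CC1(CO)CO`: > 20000 nM
compound 2, `CCCCSc1nc(N)nc2c1ncn2/C=C1/CC1(CO)CO`: > 20000 nM
compound 3, `CC(C)CNc1nc(N)nc2c1ncn2/C=C1/CC1(CO)CO`: "not determined" (no result reported)

In an ADME assay on MOLT-3 cells (Homo sapiens) for cytotoxicity, with a stated time of 7 days (a higher number here means that more compound is tolerated, a lower number that less compound is tolerated), compound 1 reaches only the limit of the assay, > 20000 nM. Compound 2 likewise sits at the limit of the assay, > 20000 nM. Compound 3 has no result in this assay. The step that the two limits leave unreadable from compound 1 to compound 2 is therefore unreadable. Compound 2 thus stands at the limit of > 20000 nM in this assay, at which 2 of the 3 values shown sit, with no value that resolves it further.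

Compound 4, `CCCCCCCCSc1nc(N)nc2c1ncn2/C=C1/CC1(CO)CO`, differs from compound 2 by butyl in place of hydrogen on a saturated chain carbon, four bonds along the chain from a sulfur. Going by the values given here, no measured step bears on this change: compound 1 and compound 2 both sit at the limit. Compound 4 is therefore expected to remain at the limit as well. The step of a number no higher from compound 2 to compound 4 (the limit leaves the size open) is expected to be none beyond the scatter. For compound 4 the estimate is 20000 nM, with a range from 10000 nM to 40000 nM.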

Compound 4, half-maximal cytotoxic concentration: > 20000 nM
Compound 4 ended at the assay's limit; the forecaster's own chance of this, stated with the estimate: 85%; the middle value sits exactly at the limit.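

No new step can be read among compound 1, compound 2 and compound 4 in this assay: the limit of > 20000 nM in this assay, at which 3 of the 4 values shown sit.

The compounds shown leave open where the tolerated concentration of each one actually lies, and whether any of these changes alters it at all.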